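The compounds below may be only part of what the source reports. "The series", "measured", "known", "first", "only" and "open" are said of these compounds alone.

Compound 1, with the structure `Cc1ccc(-c2ccc(C(O)CCCCCO)cc2)cc1`, and compound 2, with the structure `OCCCCCC(O)c1ccc(-c2ccc(Cl)cc2)cc1`, were both examined in a functional assay on J774 cells (Mus musculus) for cytotoxicity, read by resazurin assay; on this read-out higher numbers stand for weaker inhibition and lower numbers for stronger inhibition. In this assay compound 1 gives 22000 nM, and compound 2 gives 17000 nM. The two differ at a single point, as set out here: chloro in place of methyl on an aromatic carbon. The step that accompanies this change is a 1.3-fold lower number from compound 1 to compound 2 (0.11 log units; within the scatter), so the two values cannot be told apart with confidence.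

Compound 3, with the structure `Cc1cc(F)ccc1-c1ccc(C(=O)CCCCCO)cc1`, belongs to the same series but carries a different core; the difference between the core of compound 3 and the core of compound 1 is not broken down here. In this assay compound 3 gives 20000 nM, which sits close to the values of compound 1 and compound 2.

Compound 4, with the structure `O=C(CCCCCO)c1ccc(-c2ccc(F)cc2Cl)cc1`, has not yet been measured in this assay. It differs from compound 3 in one place, as follows: chloro in place of methyl on an aromatic carbon. Among the compounds with values here, this is the same kind of change as the one from compound 1 to compound 2, but the surroundings are not identical: in compound 2 the chloro group stands para to a large group, whereas in compound 4 it stands ortho to a large group and meta to a fluoro group. Because the earlier change gave a 1.3-fold lower number from compound 1 to compound 2 (0.11 log units; within the scatter), the step from compound 3 to compound 4 is expected to be small as well, roughly a 1.1-fold lower number from compound 3 to compound 4 (0.05 log units; within the scatter). On that basis compound 4 is estimated to give about 18000 nM in this assay, with a plausible range from 9000 nM to 36000 nM.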

Compound 4, half-maximal inhibitory concentration: 15000 nM
Compound 4: the middle estimate sits 1.2-fold (0.08 log units) above what was measured; the measured number falls inside the stated range.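

In this assay the exchange of methyl for chloro on an aromatic carbon comes with a 1.3-fold lower number from compound 3 to compound 4 (0.12 log units; within the scatter), and the comparison with the earlier case of the same exchange finds the two steps in agreement: the same change on two cores in this assay, a 1.3-fold lower number (0.11 log units; within the scatter) from compound 1 to compound 2 and a 1.3-fold lower number (0.12 log units; within the scatter) from compound 3 to compound 4, 1.0-fold (0.01 log units) apart, within the scatter of two such steps On the core of compound 1 and on the core of compound 3 alike, then, this exchange leaves the number within the scatter, so the result carries over between these two cores in the limited sense that neither shows a step that can be told from noise. It does not show that chloro and methyl have any real difference in this read-out, and two pairs, with the chloro group in different surroundings, give no rule for other cores or other places on the ring.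

The compounds shown leave open whether a group such as trifluoromethyl or methoxy in the same place, rather than chloro, would give a step beyond the scatter. As far as these compounds go, it also remains open whether an amine or a carboxylic acid in place of the alcohol at the end of the chain, or a longer chain, would move the number.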